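The compounds below may be only part of what the source reports. "The series", "measured", "known", "first", "only" and "open" are said of these compounds alone.

Measured compounds:
- compound 1 `CCS(=O)(=O)c1ccc(CNC(=O)c2ccc3c(c2)cc(Cc2ccccc2C(F)(F)F)n3C(C)C)cc1` gives 0.717 h in an ADME assay on microsomes from liver (Rattus norvegicus) for metabolic stability; a lower number here means that the compound disappears faster, a higher number that the compound lasts longer
- compound 2 `CCS(=O)(=O)c1ccc(CNC(=O)c2ccc3c(c2)cc(Cc2ccc(F)cc2C(F)(F)F)n3C(C)C)cc1` gives 1.07 h in this assay
- compound 3 `CCS(=O)(=O)c1ccc(CNC(=O)c2ccc3c(c2)cc(Cc2ccccc2OC)n3C(C)C)cc1` gives 0.2 h in this assay

Compound 2 has the highest number of the three in this assay, though its gap to compound 1, a 1.5-fold higher number from compound 1 to compound 2 (0.17 log units; within the scatter), lies within the scatter; only compound 3 stands clearly apart, with a 5.4-fold lower number from compound 2 to compound 3 (0.73 log units; beyond the scatter). Compound 4 `CCS(=O)(=O)c1ccc(CNC(=O)c2ccc3c(c2)cc(Cc2ccc(Cl)cc2C(F)(F)F)n3C(C)C)cc1` differs from compound 2 in one place: chloro in place of fluoro on an aromatic carbon. Going by the values given here, none of the measured steps exchanges one halogen for another. The nearest comparison is the step from compound 1 to compound 2, in which a 1.5-fold higher number from compound 1 to compound 2 (0.17 log units; within the scatter) shows that putting fluoro onto that carbon moved the number within the scatter. The larger steps of a 3.6-fold lower number from compound 1 to compound 3 (0.55 log units; beyond the scatter) and a 5.4-fold lower number from compound 2 to compound 3 (0.73 log units; beyond the scatter) concern the methoxy replacement and do not bear on the chloro for fluoro exchange. Compound 4 is therefore expected to land close to compound 2, with a step of a 1.1-fold lower number from compound 2 to compound 4 (0.03 log units; within the scatter) that stays within the scatter. The estimate for compound 4 in this assay is 1 h, with a range from 0.5 h to 2 h.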

Compound 4, half-life: 1.93 h
For compound 4 the middle estimate is 1.9-fold (0.29 log units) below the measured one; the measured number falls inside the stated range.
By their numbers in this assay, from the lowest: compound 3; then compounds 1, 2 and 4 (each within the scatter of the next, the first and the last beyond it).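

At the aromatic carbon meta to a trifluoromethyl group and para to a large group, chloro in place of fluoro gives a 1.8-fold higher number from compound 2 to compound 4 (0.26 log units; within the scatter) in this assay, so this assay does not separate the two halogens at this position. Against hydrogen, however, chloro gives a 2.7-fold higher number from compound 1 to compound 4 (0.43 log units; beyond the scatter), a separation that fluoro at the same carbon did not reach, and replacing 2-methoxyphenyl with 4-chloro-2-(trifluoromethyl)phenyl gives a 9.7-fold higher number from compound 3 to compound 4 (0.98 log units; beyond the scatter) as the widest step in the set. No measurement at hand explains these differences.

Going by these compounds, whether a methyl group or a nitrile on that carbon would also stand clear of hydrogen remains open. So does whether chloro would have a similar effect on the 2-methoxyphenyl ring of compound 3.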